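A few compounds are considered here, and "the series" means these few. Any claim that something is new, unique, unknown or untested is made for them only; others in the source may bear on it.

Working notes on the series. In an assay on isolated protein for displacement of a labelled ligand from melanin-concentrating hormone receptor 1 (Homo sapiens) (on this read-out higher numbers stand for weaker inhibition and lower numbers for stronger inhibition), compound 1 `O=C(CCc1ccc(C(F)(F)F)cc1)Nc1ccc2nc(N3CCCCC3)ccc2c1` gives 12 nM, compound 2 `CN(C)c1ccc2cc(NC(=O)CCc3ccc(C(F)(F)F)cc3)ccc2n1` gives 13 nM, and compound 3 `CC(=O)NC1CCN(c2ccc3cc(NC(=O)CCc4ccc(C(F)(F)F)cc4)ccc3n2)C1` gives 5 nM. Compound 3 holds the lowest of the three numbers: a 2.4-fold lower number from compound 1 to compound 3 (0.38 log units; beyond the scatter) and a 2.6-fold lower number from compound 2 to compound 3 (0.41 log units; beyond the scatter), both beyond the scatter, whereas a 1.1-fold higher number from compound 1 to compound 2 (0.03 log units; within the scatter).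

Compound 4 `O=C(CCc1ccc(C(F)(F)F)cc1)Nc1ccc2nc(N3CC4CC3CO4)ccc2c1` has not yet been measured. Its change from compound 3 is a group of 7 heavy atoms (5 carbon, 1 nitrogen, 1 oxygen; 2 five-membered non-aromatic rings with 1 hetero atom each) in place of a group of 9 heavy atoms (6 carbon, 2 nitrogen, 1 oxygen; one five-membered non-aromatic ring with 1 hetero atom), on an aromatic carbon. All three measured steps vary the group on this same aromatic carbon, so each bears on the present step. The groups of compound 1 and compound 2, which lack the acetamido part of the 3-acetamidopyrrolidin-1-yl group, sit a modest step above compound 3, and the entering group likewise carries no hydrogen-bond donor. Within the data shown here, the expectation in this assay is therefore a modest rise back toward the numbers of compound 1 and compound 2, a 2.0-fold higher number from compound 3 to compound 4 (0.30 log units; within the scatter), though a bicyclic group of this kind has no precedent here. For compound 4 the estimate in this assay is 10 nM, with a range of 4 nM to 30 nM.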

Compound 4, half-maximal inhibitory concentration: 13 nM
Compound 4: middle estimate off by 1.3-fold (0.11 log units), on the low side; the measured number falls inside the stated range.
By their numbers in this assay, from the lowest: compound 3; then compounds 1, 2 and 4 (each within the scatter of the next).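

In this assay the change reads a 2.6-fold higher number from compound 3 to compound 4 (0.41 log units; beyond the scatter), while the other two new steps read no change at the digits printed from compound 2 to compound 4 (within the scatter) and a 1.1-fold higher number from compound 1 to compound 4 (0.03 log units; within the scatter). A group with 2 five-membered non-aromatic rings and 0 hydrogen-bond donors thus stands level with the dimethylamino and piperidin-1-yl groups on this aromatic carbon, and among these four compounds only the 3-acetamidopyrrolidin-1-yl group of compound 3 stands apart. Nothing on hand accounts for that separation.

Whether the separation follows the acetamido part or the pyrrolidin-1-yl part stays open, as no group shown carries the latter without the former. An unsubstituted pyrrolidin-1-yl, a 3-aminopyrrolidin-1-yl or a 3-hydroxypyrrolidin-1-yl group on this carbon would tell the two apart.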